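From a Secondary Amide to a Piperidine Amide

The source may hold more compounds than are shown below. What is called first, only, known or untested is meant among the compounds shown, and "the series" means these compounds.

Compound 1 `CCC(CC)S(=O)(=O)c1ccc(S(=O)(=O)N2CCC[C@@H](C(=O)N3CCC(F)(F)CC3)C2)cc1`: 40 nM
Compound 2 `CCN(CC)S(=O)(=O)c1ccc(S(=O)(=O)N2CCC[C@@H](C(=O)N[C@H]3CC[C@H](OC)CC3)C2)cc1`: 2000 nM
Compound 3 `O=C([C@@H]1CCCN(S(=O)(=O)c2ccc(S(=O)(=O)N3CC[C@H](O)C3)cc2)C1)N1CCC(F)(F)CC1`: 580 nM

Of the compounds shown here, three have been measured in a functional assay on BXPC-3 cells (Homo sapiens) for inhibition, read by MTT assay, with a stated time of 7 days; a higher number here means a weaker inhibitor, a lower number a stronger inhibitor. Compound 2 stands at the highest number of the three, with compound 3 the nearest and compound 1 the furthest from it. For the measured compounds named here, the one step that can be read in isolation, a 15-fold higher number from compound 1 to compound 3 (1.16 log units; beyond the scatter), concerns a substituent on a sulfonyl sulfur and not the carbonyl carbon, so it does not bear directly on the change considered here.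

Compound 4 `CCN(CC)S(=O)(=O)c1ccc(S(=O)(=O)N2CCC[C@@H](C(=O)N3CCC(COC)CC3)C2)cc1` differs from compound 2 as follows: 4-(methoxymethyl)piperidin-1-yl in place of (4-methoxycyclohexyl)amino on a carbonyl carbon. Going by the values given here, the new amide partner is a piperidin-1-yl group, and the two compounds that carry a piperidin-1-yl amide, compound 1 and compound 3, both give lower numbers in this assay than compound 2; but each of them also differs from compound 2 on the sulfonyl sulfur, so no single step isolates the amide change. The expectation for compound 4 is therefore a lower number than compound 2, with wide uncertainty, and the step is estimated as a 3.3-fold lower number from compound 2 to compound 4 (0.52 log units; beyond the scatter). Compound 4 is expected to give about 600 nM, within a range of 150 nM to 2500 nM.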

Compound 4, half-maximal inhibitory concentration: 1360 nM
Beside the measured number, compound 4's estimate is 2.3-fold (0.36 log units) below it, within the range that was stated.
By their numbers in this assay, from the lowest: compound 1; then compound 3; then compounds 4 and 2 (each within the scatter of the next).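

In this assay, for the compounds shown here, the exchange on the carbonyl carbon can for the first time be read on its own, with the rest of the molecule held constant, and it gives a 1.5-fold lower number from compound 2 to compound 4 (0.17 log units; within the scatter). The entering 4-(methoxymethyl)piperidin-1-yl group has the same count of heavy atoms as the leaving (4-methoxycyclohexyl)amino group but carries no hydrogen-bond donor where the leaving group carries one, and in this pair neither that difference nor the move to a piperidin-1-yl amide separates the two compounds beyond the scatter. No measurement is available that would explain this outcome.

The compounds shown leave open how much of the distance to compound 1, at 40 nM, belongs to its amide partner and how much to the group on its sulfonyl sulfur, since compound 1 differs from compound 2 and compound 4 in both places. Going by these compounds, it also remains open whether a morpholine amide, or a piperidine amide carrying a primary amine, a carboxylic acid or a longer ether chain, would produce a step beyond the scatter at this carbonyl carbon.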